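Cytotoxicity notes on a quinoline series: compound 4

This account rests on a few compounds, and the source may have more. Where it says the series, first, only, none or still open, it means among the compounds named here.

Measured compounds and their values:
- Compound 1, `COc1ccc(F)cc1CNCCCNc1ccnc2cc(Cc3cc(C)cc(C)c3)ccc12`: 940 nM
- Compound 2, `COc1ccc(F)cc1CNCCCNc1ccnc2cc(CC(C)C)ccc12`: 2900 nM
- Compound 3, `COc1ccc(-c2ccc3c(NCCCNCc4cc(F)ccc4OC)ccnc3c2)cc1`: 5960 nM

In an ADME assay on HepG2 cells (Homo sapiens) for cytotoxicity, read by luminescence, CellTiter-Glo and ATP content, with a stated time of 72 h (on this read-out higher numbers stand for an effect only at larger amounts of compound and lower numbers for an effect already at smaller amounts), compound 3 gives the highest number of the three; its nearest neighbour is compound 2, as a 2.1-fold higher number from compound 2 to compound 3 (0.31 log units; beyond the scatter) shows, and the furthest is compound 1, as a 6.3-fold higher number from compound 1 to compound 3 (0.80 log units; beyond the scatter) shows. Compound 4, `COc1ccc(F)cc1CNCCCNc1ccnc2cc(Oc3cccc(N(C)C)c3)ccc12`, has not been measured. It differs from compound 3 by 3-(dimethylamino)phenoxy in place of 4-methoxyphenyl on an aromatic carbon.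

The measured steps that bear on this change are the two that lead into compound 3, a 6.3-fold higher number from compound 1 to compound 3 (0.80 log units; beyond the scatter) and a 2.1-fold higher number from compound 2 to compound 3 (0.31 log units; beyond the scatter), both of which raised the number when 4-methoxyphenyl entered. Going by the values given here, no measured step involves the entering 3-(dimethylamino)phenoxy, so the direction of this exchange is not anchored. Both groups carry one six-membered aromatic ring of carbon only; the step of a 1.3-fold lower number from compound 3 to compound 4 (0.12 log units; within the scatter) is therefore expected to be small, most likely within the scatter, with a slight downward lean. For compound 4 the expected value is 4500 nM, in the range 1800 nM to 11000 nM.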

Compound 4, half-maximal effective concentration: 3300 nM
The estimate for compound 4 lay 1.4-fold (0.13 log units) above the measured number, and the stated range covers the measured number.
By their numbers in this assay, from the lowest: compound 1; then compounds 2, 4 and 3 (each within the scatter of the next, the first and the last beyond it).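

In this assay the 3-(dimethylamino)phenoxy group gives the first phenoxy data point on this aromatic carbon, and compound 4 cannot be separated from the compounds carrying 4-methoxyphenyl (a 1.8-fold lower number from compound 3 to compound 4 (0.26 log units; within the scatter)) or isobutyl (a 1.1-fold higher number from compound 2 to compound 4 (0.06 log units; within the scatter)). Only the 3,5-dimethylbenzyl group stands apart from it (a 3.5-fold higher number from compound 1 to compound 4 (0.55 log units; beyond the scatter)), so compound 1 remains alone at the low end of the four, with compounds 2, 3 and 4 not forming a clear order among themselves. Nothing at hand accounts for these numbers.

Whether the oxygen link or the dimethylamino group matters on its own stays open, since the compounds shown hold no phenoxy group without the dimethylamino group. Also open, from the compounds shown here alone, is how a carboxylic acid or a morpholine on this aromatic carbon would read.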